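From Isopropylsulfanyl to (tert-Butyl)sulfanyl on the Carbonyl

The source may report more compounds than this note shows. Statements on the series, on what has been measured and on what is new or still open speak of the compounds shown alone.

Of the compounds shown here, two have been measured so far. Compound 1 `Cc1nc(S(C)(=O)=O)ccc1Oc1ncnc(OC2CCN(C(=O)OC(C)(C)C#N)CC2)c1F` gives 92.9 nM in a functional assay on isolated protein for inhibition of Glucose-dependent insulinotropic receptor (Homo sapiens), read by HTRF and cAMP accumulation; on this read-out higher numbers stand for an effect only at larger amounts of compound and lower numbers for an effect already at smaller amounts. Among the measured compounds shown here, compound 2 `Cc1nc(S(C)(=O)=O)ccc1Oc1ncnc(OC2CCN(C(=O)SC(C)C)CC2)c1F` gives 6.8 nM in this assay, the lowest of the two numbers; its only neighbour is compound 1, and the step of a 14-fold lower number from compound 1 to compound 2 (1.14 log units; beyond the scatter) separates the pair. Compound 3 `Cc1nc(S(C)(=O)=O)ccc1Oc1ncnc(OC2CCN(C(=O)SC(C)(C)C)CC2)c1F` has not yet been measured. It differs from compound 2 by methyl in place of hydrogen on a saturated chain carbon bound to two saturated chain carbons and a sulfur; cut one bond further out, the change reads isopropylsulfanyl to (tert-butyl)sulfanyl on the carbonyl. For the measured compounds named here, the single measured step, a 14-fold lower number from compound 1 to compound 2 (1.14 log units; beyond the scatter), exchanged the whole group on that carbonyl and was large, but no measured step tests one added methyl within a sulfur-bound chain, so that step bears only loosely on the present one. The expected step of a 1.0-fold lower number from compound 2 to compound 3 (0.02 log units; within the scatter) is therefore small, in no firm direction, and within the scatter of repeated measurements. Compound 3 is estimated at 6.5 nM in this assay, with a range from 2.5 nM to 18 nM.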

Compound 3, half-maximal effective concentration: 4.83 nM
Compound 3: middle estimate off by 1.3-fold (0.13 log units), on the high side, within the range that was stated.
By their numbers in this assay, from the lowest: compounds 3 and 2 (each within the scatter of the next); then compound 1.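

Adding methyl on a saturated chain carbon bound to two saturated chain carbons and a sulfur, which turns isopropylsulfanyl into (tert-butyl)sulfanyl, gives the first test of a change within the sulfur-bound chain, and in this assay it yields a 1.4-fold lower number from compound 2 to compound 3 (0.15 log units; within the scatter), so this added methyl cannot be told apart from the scatter. The large separation from the 1-cyano-1-methylethoxy group on the carbonyl carbon also holds for the (tert-butyl)sulfanyl group, with a 19-fold lower number from compound 1 to compound 3 (1.28 log units; beyond the scatter), so compound 2 and compound 3 both stand well clear of compound 1 on the same side. No evidence is at hand that bears on what lies behind these numbers.

The compounds shown leave open whether the sulfur or the chain on it accounts for the gap to compound 1, a question that a tert-butoxy group on the same carbonyl carbon would address directly. They also leave open how a smaller methylsulfanyl group, a longer n-butylsulfanyl chain or an amine such as dimethylamino on that carbonyl would read, while the shared core stays the same throughout.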